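A Larger Group in Place of the Nitrile

The source may hold more compounds than are shown below. What is called first, only, known or untested is meant among the compounds shown, and "the series" means these compounds.

Of the compounds shown here, two have so far been measured in a functional assay for antagonist activity at transient receptor potential cation channel subfamily V member 1 (Rattus norvegicus); on this read-out higher numbers stand for weaker inhibition and lower numbers for stronger inhibition. Compound 1 `C[C@@H]1CN(c2ncccc2C(F)(F)F)CCN1C(=O)Nc1ccc(C(F)(F)F)cc1` gives 11 nM. Compound 2 `CC(C)(C)c1ccc(NC(=O)c2ccc(-c3ncccc3C#N)cc2)cc1` gives 13 nM, the higher of the two numbers, though its gap to compound 1 lies within the scatter, so the two cannot be ranked against each other. Compound 3 `CC(C)(C)c1ccc(NC(=O)c2ccc(-c3ncccc3NS(=O)(=O)c3ccccc3)cc2)cc1` has not yet been measured. It differs from compound 2 in one place: (phenylsulfonyl)amino in place of cyano on an aromatic carbon. The group that enters is far larger than the group that leaves, and it sits ortho to a large group, two atoms from the ring nitrogen. Within the data shown here, no measured pair shows a change of this kind, so the direction of the step cannot be read from the numbers at hand. A moderate loss of potency seems the more likely outcome, and the estimated step is a 3.1-fold higher number from compound 2 to compound 3 (0.49 log units; beyond the scatter). Compound 3 is therefore expected to give about 40 nM, within a range from 8 nM to 300 nM.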

Compound 3, half-maximal inhibitory concentration: 166 nM
Compound 3: middle estimate off by 4.2-fold (0.62 log units), on the low side; measured number inside the range.
By their numbers in this assay, from the lowest: compounds 1 and 2 (each within the scatter of the next); then compound 3.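

In this assay this position proves sensitive to what stands on it: (phenylsulfonyl)amino in place of cyano gives a 13-fold higher number from compound 2 to compound 3 (1.11 log units; beyond the scatter), a large step. The change does not abolish inhibition, however, as compound 3 still gives 166 nM in this assay. Nothing available bears on why the number rises.

The entering group differs from cyano at once in its heavy atoms, its six-membered aromatic ring, and its hydrogen-bond donor, so this single step cannot separate their contributions. On these data alone, it remains open whether a plain amine or a methylsulfonylamino group on this aromatic carbon would give a number closer to that of compound 2 or to that of compound 3.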